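Methyl to Cyclopropyl on a Fused Saturated Core

The source may report more compounds than this note shows. Statements on the series, on what has been measured and on what is new or still open speak of the compounds shown alone.

Compound 1 `CC(=O)N[C@@H]1CCCc2c1cncc2N1C(=O)c2ccc(Cl)cc2[C@H]1C`: 130 nM
Compound 2 `N#Cc1ccc2c(c1)CN(c1cccnc1)C2=O`: 232 nM

In an assay on cells for inhibition of cytochrome P450 11B2, mitochondrial (Homo sapiens), read by HTRF (on this read-out lower numbers stand for stronger inhibition and higher numbers for weaker inhibition), compound 1 stands at 130 nM, and compound 2 at 232 nM; the gap between them lies within the usual scatter, so neither can be called stronger. Compound 3 `CC(=O)N[C@@H]1CCCc2c1cncc2N1C(=O)c2ccc(Cl)cc2[C@H]1C1CC1` is not yet measured. It differs from compound 1 by cyclopropyl in place of methyl on a saturated ring carbon. Going by the values given here, no measured pair shows a step of this kind, so its size is unknown; a shift no larger than the scatter, in either direction, is expected. Compound 3 is therefore estimated at 110 nM, in a range from 35 nM to 350 nM, which means an expected step of a 1.2-fold lower number from compound 1 to compound 3 (0.07 log units; within the scatter).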

Compound 3, half-maximal inhibitory concentration: 100 nM
For compound 3 the middle estimate is 1.1-fold (0.04 log units) above the measured one, and the stated range covers the measured number.
By their numbers in this assay, from the lowest: compounds 3, 1 and 2 (each within the scatter of the next, the first and the last beyond it).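

At this saturated ring carbon, next to the ring nitrogen, cyclopropyl with its 3 heavy atoms can stand in place of the single carbon of methyl, and this assay shows only a 1.3-fold lower number from compound 1 to compound 3 (0.11 log units; within the scatter). In this one pair, the position therefore accepts a three-membered ring with no change beyond the scatter. Nothing measured here offers an explanation for this result.

Going by these compounds, it remains open whether a longer chain, such as n-butyl, or a group carrying an amine or a carboxylic acid, would fit at this carbon equally well.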